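The source may hold more compounds than are shown below. What is called first, only, known or untested is meant among the compounds shown, and "the series" means these compounds.

Compound 3 `C=CC(=O)NCc1coc(-c2c(N)ncnc2Nc2ccc(Oc3cccnc3)c(Cl)c2)n1` gives the lowest of the three numbers in an in vitro ADME assay on microsomes from liver (Rattus norvegicus) for metabolic stability, tested at 5 uM (a higher number here means that the compound lasts longer, a lower number that the compound disappears faster), at 0.15 h. Compound 1 `C=CC(=O)NCc1coc(-c2c(N)ncnc2Nc2ccc(Oc3cccc(F)c3)c(Cl)c2)n1` gives 0.9 h in this assay, and compound 2 `C=CC(=O)NCc1coc(-c2c(N)ncnc2Nc2ccc(Oc3ccc(F)cc3)c(Cl)c2)n1` gives 1.1 h; the step of a 1.2-fold higher number from compound 1 to compound 2 (0.09 log units; within the scatter) lies within the scatter, whereas the steps of a 6.0-fold lower number from compound 1 to compound 3 (0.78 log units; beyond the scatter) and a 7.3-fold lower number from compound 2 to compound 3 (0.87 log units; beyond the scatter) lie beyond it. Compound 4 `C=CC(=O)NCc1coc(-c2c(N)ncnc2Nc2ccc(F)c(Cl)c2)n1` differs from compound 3 by fluoro in place of (pyridin-3-yl)oxy on an aromatic carbon. Going by the values given here, no measured step removes the whole aryloxy group; the two steps that bear on the change only exchange a fluorophenyl for a pyridin-3-yl, and both lowered the number by a modest amount. Expected for compound 4 is a 4.7-fold higher number from compound 3 to compound 4 (0.67 log units; beyond the scatter), upward though uncertain in size. Compound 4 is estimated at 0.7 h, within 0.25 h to 2 h.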

Compound 4, half-life: 0.4 h
Compound 4: middle estimate off by 1.8-fold (0.24 log units), on the high side, within the range that was stated.
By their numbers in this assay, from the lowest: compound 3; then compound 4; then compounds 1 and 2 (each within the scatter of the next).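

In this assay, replacing the whole aryloxy group with fluoro has no single direction: the change gives a 2.7-fold higher number from compound 3 to compound 4 (0.43 log units; beyond the scatter) when (pyridin-3-yl)oxy leaves, but a 2.8-fold lower number from compound 2 to compound 4 (0.44 log units; beyond the scatter) and a 2.3-fold lower number from compound 1 to compound 4 (0.35 log units; beyond the scatter) when a fluorophenoxy group leaves. At this position, then, the outcome depends on which aryloxy group is replaced, and both fluorophenoxy groups give higher numbers than fluoro does. Nothing shown explains this order. Going by these compounds, it remains open how a methoxy group, an amine or an unsubstituted phenoxy group at this position would compare.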